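Flipping both double bonds from Z to E

This account rests on a few compounds, and the source may have more. Where it says the series, first, only, none or still open, it means among the compounds named here.

Three compounds form the starting set for this comparison. In a functional assay on OVCAR-3 cells (Homo sapiens) for antiproliferative activity, read by WST assay, with a stated time of 72 h, in the presence of a further agent that is not named here (on this read-out lower numbers stand for stronger inhibition and higher numbers for weaker inhibition), compound 2 `CCCCCCCCCCc1c(C)c(CCCCCCCCCC)c2[n+](c1C)CCC2` gives 300 nM, while compound 3 `CCCCCCCC/C=C\c1c(C)c(/C=C\CCCCCCCC)c2[n+](c1C)CCC2` gives 860 nM. Compound 3 therefore holds the higher of the two numbers, and its gap to compound 2 lies beyond the usual scatter. Compound 1 `CCCCCCCC/C=C\c1c(C)nc(C)c(/C=C\CCCCCCCC)c1C` adds no number, its entry reading "not determined" (no result reported).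

The next compound is compound 4 `CCCCCCCC/C=C/c1c(C)c(/C=C/CCCCCCCC)c2[n+](c1C)CCC2`. Between compound 3 and compound 4, (the two compounds have the same atoms and bonds and differ only in configuration as drawn: 2 of 2 stereo elements differ; a double bond is drawn Z in compound 3 and E in compound 4; a double bond is drawn Z in compound 3 and E in compound 4). The two compounds thus have the same atoms and bonds and differ only in configuration as drawn.

Within the data shown here, no measured pair in this set shows what such a change does in this assay, so any forecast is weakly grounded. Among the measured compounds shown here, the only guide is the span of the measured numbers, from compound 2 at 300 nM to compound 3 at 860 nM. A step beyond the scatter is not expected, though a slight lean toward the lower number seems plausible. The expected step is a 1.4-fold lower number from compound 3 to compound 4 (0.16 log units; within the scatter). For compound 4 the estimated value is 600 nM, with an expected range from 200 nM to 1600 nM.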

Compound 4, half-maximal inhibitory concentration: 700 nM
Compound 4: the middle estimate sits 1.2-fold (0.07 log units) below what was measured; measured number inside the range.
By their numbers in this assay, from the lowest: compound 2; then compounds 4 and 3 (each within the scatter of the next).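

In this assay, changing both double bonds from Z to E gives a 1.2-fold lower number from compound 3 to compound 4 (0.09 log units; within the scatter). Among these compounds, this is the first pair in the set whose members differ in one feature only, and so the first direct reading of what the configuration of these two chains does on the shared core. The reading is that this read-out does not separate the all-Z and all-E forms, and any gap between them could come only from configuration, which leaves no room for another structural change to account for it: the fact that compounds 3 and 4 differ only in the configuration as drawn

The compounds shown leave open what a single flip would do, with one double bond drawn Z and the other drawn E, as both change together in this pair. They also leave open whether the same result would hold for a longer chain, for a triple bond in place of each double bond, or for a chain ending in a carboxylic acid or an amine.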